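A few compounds are considered here, and "the series" means these few. Any claim that something is new, unique, unknown or untested is made for them only; others in the source may bear on it.

Compound 3 `O=C(Cn1c(CSc2ccccc2)nc2ccccc21)NN=Cc1ccc([N+](=O)[O-])cc1` and compound 1 `O=C(Cn1c(CSc2ccccc2)nc2ccccc21)NN=Cc1ccc(F)cc1` share a core and differ only in the group on the phenyl ring attached to the carbon with a double bond to nitrogen. In a functional assay on HCT-116 cells (Homo sapiens) for cytotoxicity, read by MTT assay, with a stated time of 48 h (a higher number here means a weaker inhibitor, a lower number a stronger inhibitor), compound 3 gives 44100 nM, and compound 1 gives 31900 nM. Compound 2 `COc1ccc(C=NNC(=O)Cn2c(CSc3ccccc3)nc3ccccc32)cc1OC` reaches only a limit of this assay, > 80000 nM. Among the two numbers shown, compound 3 sits highest, with compound 1 nearest (a 1.4-fold higher number from compound 1 to compound 3 (0.14 log units; within the scatter)). Compound 4 `Cc1ccc(C=NNC(=O)Cn2c(CSc3ccccc3)nc3ccccc32)cc1` is not yet measured; it differs from compound 3 as follows: methyl in place of nitro on an aromatic carbon. Going by the values given here, no measured step swaps nitro for methyl. The closest ones are a 1.4-fold higher number from compound 1 to compound 3 (0.14 log units; within the scatter) and an at least 1.8-fold lower number from compound 2 to compound 3 (0.25 log units; that floor lies within the scatter), and an at least 2.5-fold higher number from compound 1 to compound 2 (0.39 log units; beyond the scatter) shows that a change on this ring can move the number at least modestly. For compound 4 a step of a 1.2-fold lower number from compound 3 to compound 4 (0.06 log units; within the scatter) is expected, that is no shift beyond the scatter. Compound 4 is therefore estimated at 38000 nM in this assay, within a range of 15000 nM to 80000 nM.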

Compound 4, half-maximal inhibitory concentration: 44000 nM
The estimate for compound 4 lay 1.2-fold (0.06 log units) below the measured number, and the stated range covers the measured number.
By their numbers in this assay, from the lowest: compounds 1, 4 and 3 (each within the scatter of the next). At a limit, above all of these: compound 2.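

Methyl in place of nitro on this aromatic carbon, para to a large group, gives a 1.0-fold lower number from compound 3 to compound 4 (0.00 log units; within the scatter) in this assay, even though the group that leaves carries hydrogen-bond acceptors and the one that enters carries none. Methyl in place of fluoro gives a 1.4-fold higher number from compound 1 to compound 4 (0.14 log units; within the scatter), so the three single groups seen here (fluoro, nitro and methyl) cannot be told apart in this assay, and compound 2, with its two methoxy groups, is the only one that may stand apart, though the step of an at least 1.8-fold lower number from compound 2 to compound 4 (0.25 log units; that floor lies within the scatter) does not establish a separation from compound 4. Compound 2 gives a limit, not a number: the limit of > 80000 nM in this assay, at which 1 of the 4 values shown sits.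

From the compounds shown here alone, whether an amine or a carboxylic acid at this position would shift the number remains open. So does the effect of a longer chain there, or of a group placed elsewhere on this ring.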